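This account rests on a few compounds, and the source may have more. Where it says the series, first, only, none or still open, it means among the compounds named here.

Working notes on the series. In a functional assay on MCF7 cells (Homo sapiens) for antiproliferative activity, read by sulforhodamine B assay, with a stated time of 48 h (on this read-out higher numbers stand for weaker inhibition and lower numbers for stronger inhibition), compound 1 (`O=C(CCCCCCN1C(=O)/C(=N\O)c2cc(F)ccc21)NO`) gives 1550 nM and compound 2 (`O=C(CCCCCCN1C(=O)/C(=N\O)c2cc(Cl)ccc21)NO`) gives 680 nM. Within the data shown here, the only measured single-place step, a 2.3-fold lower number from compound 1 to compound 2 (0.36 log units; beyond the scatter), is modest and puts chloro in place of fluoro on an aromatic carbon.

Compound 3 (`CO/N=C1/C(=O)N(CCCCCCC(=O)NO)c2ccccc21`) gives 1710 nM. This is level with compound 1 within the scatter and a higher number than compound 2, so compound 3 sits at the weak end of the three values.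

Compound 4 (`CO/N=C1/C(=O)N(CCCCCCC(=O)NO)c2ccc(Br)cc21`) follows from compound 3 by one change: bromo in place of hydrogen on an aromatic carbon. Only a 2.3-fold lower number from compound 1 to compound 2 (0.36 log units; beyond the scatter) bears on this change, and it is indirect evidence. It exchanges one halogen for another rather than hydrogen for a halogen, and compounds 1 and 2 also differ from compound 3 elsewhere. Among the measured compounds shown here, no measured pair shows what adding a halogen does here.

A modest move towards a lower number in this assay is therefore expected, of about the size of that step, though a result within the scatter remains possible. The estimated step is a 2.3-fold lower number from compound 3 to compound 4 (0.36 log units; beyond the scatter). For compound 4 the estimated value is 750 nM, with an expected range of 320 nM to 1600 nM.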

Compound 4, half-maximal inhibitory concentration: 7790 nM
For compound 4 the middle estimate is 10-fold (1.02 log units) below the measured one; the measured number lies above the stated range.
By their numbers in this assay, from the lowest: compound 2; then compounds 1 and 3 (each within the scatter of the next); then compound 4.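

In this assay, among these compounds, the step from hydrogen to bromo gives the first direct reading of a halogen entering this aromatic carbon, and a 4.6-fold higher number from compound 3 to compound 4 (0.66 log units; beyond the scatter) is a move towards weaker inhibition. The earlier 2.3-fold lower number from compound 1 to compound 2 (0.36 log units; beyond the scatter) exchanges one halogen for another on a different oxime group, and the new step shows that its direction does not carry over to adding bromo to compound 3. At this position, then, the effect of a halogen on the methoxyimino series has to be read from compound 3 and compound 4 themselves, and the data at hand give no measurement that accounts for the size or direction of this step.

Open, as far as these compounds go, is whether the rise belongs to bromo alone or also appears with fluoro, chloro, methyl or an amine on the same aromatic carbon of compound 3. Also open, from the compounds shown here alone, is whether bromo has the same effect when the methoxyimino group is replaced by the hydroxyimino group of compound 1, or when the chain carrying the hydroxamic acid is shorter or longer.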